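Furan-2-yl Replacing 4-Hydroxyphenyl in Compound 4

The source may report more compounds than this note shows. Statements on the series, on what has been measured and on what is new or still open speak of the compounds shown alone.

Compound 3 `CCn1cc(C(=O)N2N=C(c3cc4ccccc4o3)CC2c2ccc(O)cc2)c(=O)c2ccc(C)nc21` was tested in an ADME assay on Vero cells (Chlorocebus sabaeus) for cytotoxicity, read by MTT assay, with a stated time of 72 h; a higher number here means a weaker inhibitor, a lower number a stronger inhibitor. There compound 3 gives > 148000 nM, which is a limit of the assay and not a number. Compound 2 `CCn1cc(C(=O)N2N=C(c3cc4ccccc4o3)CC2c2cccc([N+](=O)[O-])c2)c(=O)c2ccc(C)nc21` likewise stops at a limit, > 164000 nM. Compound 1 `COc1ccccc1C1CC(c2cc3ccccc3o2)=NN1C(=O)c1ccncc1` also reaches only a limit, > 202000 nM. So compound 3 stands at a limit, and the two further values shown are limits as well; the single one-point step, a step that the two limits leave unreadable from compound 2 to compound 3, cannot be read in size for that reason.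

Compound 4 `CCn1cc(C(=O)N2N=C(c3cc4ccccc4o3)CC2c2ccco2)c(=O)c2ccc(C)nc21` is the next member and differs from compound 3 by furan-2-yl in place of 4-hydroxyphenyl on a saturated ring carbon. Among the measured compounds shown here, no measured step involves a furan-2-yl, and the only step at this saturated ring carbon is unreadable; all three values sit at limits, namely (the limit of > 148000 nM in this assay, at which 1 of the 3 values shown sits), the limit of > 164000 nM in this assay, at which 1 of the 3 values shown sits, and (the limit of > 202000 nM in this assay, at which 1 of the 3 values shown sits). With nothing readable to lean on, the account expects in this assay no step beyond the usual scatter, and the expected step from compound 3 to compound 4 is a step that the limit leaves unreadable from compound 3 to compound 4. Compound 4 is therefore estimated to give 200000 nM, within a range from 100000 nM to 400000 nM, and most probably the assay will once more report only a limit for compound 4.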

Compound 4, half-maximal inhibitory concentration: > 185000 nM
Compound 4: no number, only a limit; the forecaster's own chance of this, stated with the estimate: 85%; the middle value is on the limit's open side.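

In this assay compound 4 gives > 185000 nM, which is a limit of the assay and not a number. The steps to compound 4 from compound 3 and from compound 2 cannot be read in size. The compounds shown leave open whether the group on the saturated ring carbon changes the value in this assay at all.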